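The source may hold more compounds than are shown below. What is called first, only, known or untested is meant among the compounds shown, and "the series" means these compounds.

In an assay for binding affinity to dual specificity mitogen-activated protein kinase kinase 4 (Homo sapiens), read by KINOMEscan, tested at 10 nM (on this read-out lower numbers stand for a stronger effect and higher numbers for a weaker effect at the one concentration tested), compound 1 `CCCS(=O)(=O)Nc1ccc(F)c(C(=O)c2n[nH]c3ncc(-c4ccc(N)cc4)cc23)c1F` gives 3.7%. Compound 2 `CCCS(=O)(=O)Nc1ccc(F)c(C(=O)c2n[nH]c3ncc(-c4ccc(S(=O)(=O)NC(C)=O)cc4)cc23)c1F` gives 0.5% in this assay, and compound 3 `CCCS(=O)(=O)Nc1ccc(F)c(C(=O)c2n[nH]c3ncc(-c4ccc(-c5nnn[nH]5)cc4)cc23)c1F` gives 1.1%. On these numbers compound 1 holds the highest of the three, yet neither neighbour is separated from it beyond the scatter: a number 3.2 percentage points lower from compound 1 to compound 2 (within the scatter), and a number 2.6 percentage points lower from compound 1 to compound 3 (within the scatter). Likewise, a number 0.6 percentage points higher from compound 2 to compound 3 (within the scatter). Compound 4 `Nc1ccc(-c2cnc3[nH]nc(C(=O)c4c(F)ccc(NS(=O)(=O)Cc5ccccc5)c4F)c3c2)cc1` has not yet been measured. It differs from compound 1 in the chain carried by the sulfonyl sulfur: phenyl in place of ethyl on a saturated chain carbon bound to a sulfonyl sulfur. Going by the values given here, none of the measured steps touches this chain; each of them exchanges the group on the far aromatic ring, and each left the read-out unchanged beyond the scatter. They give no direct guide to this change. Since all three measured compounds sit at low read-outs, compound 4 is expected to remain in that low region, so a number 0.3 percentage points higher from compound 1 to compound 4 (within the scatter) is expected to be a step within the scatter. The estimate for compound 4 is 4%, ranging from 0.5% to 15%.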

Compound 4, a percentage reported as activity, at one concentration (the size of the read-out at that concentration, not a potency): 11%
Compound 4: the middle estimate sits 7 percentage points below what was measured; the measured number falls inside the stated range.
By their numbers in this assay, from the lowest: compounds 2, 3, 1 and 4 (each within the scatter of the next, the first and the last beyond it).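

Going by these compounds alone, the earlier steps all exchanged the amino group on an aromatic carbon, so this is the first reading on the sulfonyl chain. In this assay, replacing propyl with benzyl, which brings in a six-membered aromatic ring, gives a number 7.3 percentage points higher from compound 1 to compound 4 (within the scatter), so this single change does not separate the two compounds. Nothing available here explains this outcome.

A methyl group, a longer straight chain such as butyl, or a benzyl ring carrying an amine or a carboxylic acid could still behave differently at this position. Going by these compounds, it also remains open whether benzyl gives a similar reading when the amino group is replaced by acetylsulfamoyl or 1H-tetrazol-5-yl, as in compound 2 and compound 3.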